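The compounds below may be only part of what the source reports. "The series", "measured", "known", "first", "only" and "open" are said of these compounds alone.

Compound 1 `NC1=NC2(CCOCC2)N(OCCCOc2cc(Cl)c(Cl)cc2Cl)C(N)=N1`, a trichlorophenoxy compound, is a reasonably strong inhibitor in an assay on isolated protein for inhibition of Dihydrofolate reductase (Homo sapiens), read by spectrophotometry, using NADPH, with stated times of 5 s and 6 min (a higher number here means a weaker inhibitor, a lower number a stronger inhibitor), giving 36 nM. Compound 2 `NC1=NC2(CCOCC2)N(OCCCOc2ccccc2Br)C(N)=N1` carries a single bromo group on its phenoxy ring, but in this assay compound 2 gives "not determined" (no result reported), so there is no number to anchor it. Compound 3 `NC1=NC2(CCOCC2)N(OCCCOc2ccccc2)C(N)=N1` is the simplest member: hydrogen in place of bromo on an aromatic carbon. Within the data shown here, without a measured value for compound 2, no step can be drawn to compound 3, and the only reference point is compound 1 with its halogenated ring. For compound 3 a weaker inhibition is expected in this assay than that of compound 1 at 36 nM. The estimate for compound 3 is 300 nM, with a plausible range from 60 nM to 1500 nM.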

Compound 3, half-maximal inhibitory concentration: 86.1 nM
Estimate against measurement, compound 3: 3.5-fold (0.54 log units) above; the range from low to high includes it.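

In this assay, phenyl in place of 2,4,5-trichlorophenyl gives a 2.4-fold higher number from compound 1 to compound 3 (0.38 log units; beyond the scatter) and so the three chlorines are not required for nanomolar inhibition, as compound 3 still gives 86.1 nM here. The bromo-to-hydrogen step from compound 2 to compound 3 cannot be read, as compound 2 has no number. Nothing available explains the size of the chlorine step.

Going by these compounds, whether all three chlorines contribute to that step or only one of them remains open. How a methoxy group or an amine on this ring would compare is also unknown.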